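Pyrazolyl in place of butylamino on a benzazepine amide

The compounds below may be only part of what the source reports. "The series", "measured", "known", "first", "only" and "open" are said of these compounds alone.

Measured compounds:
compound 1 `CCCCNc1ccc(C(=O)N2CCCCc3ccccc32)c(Cl)c1` — 22 nM
compound 2 `O=C(c1ccc(N2CCCC2)cc1)N1CCCCc2ccccc21` — 1000 nM

In an assay on HeLa cells for binding affinity to Vasopressin V2 receptor (Homo sapiens) (on this read-out lower numbers stand for stronger inhibition and higher numbers for weaker inhibition), compound 1 gives 22 nM, the lowest of the two numbers; compound 2, which carries a pyrrolidinyl group and lacks the chloro group, gives 1000 nM, a markedly higher number beyond the scatter. Compound 3 `Cc1ccn(-c2ccc(C(=O)N3CCCCc4ccccc43)c(Cl)c2)n1` has not yet been measured in this assay. It differs from compound 1 in one place: 3-methyl-1H-pyrazol-1-yl in place of butylamino on an aromatic carbon. The shared core and the chloro group remain. Within the data shown here, no measured pair shows this change alone, so its size cannot be read from the data. Among the measured compounds shown here, the step from compound 1 to compound 3 is expected to be a weakening of moderate size, a 3.2-fold higher number from compound 1 to compound 3 (0.50 log units; beyond the scatter), since the only other compound with a changed aromatic substituent, compound 2, gives 1000 nM. Compound 3 is therefore estimated at 70 nM, within a range from 15 nM to 350 nM.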

Compound 3, half-maximal inhibitory concentration: 13 nM
The estimate for compound 3 lay 5.4-fold (0.73 log units) above the measured number, and the stated range ends above it.
By their numbers in this assay, from the lowest: compounds 3 and 1 (each within the scatter of the next); then compound 2.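

At the aromatic carbon para to a large group and meta to a chloro group, 3-methyl-1H-pyrazol-1-yl can replace butylamino without a change beyond the scatter in this assay (a 1.7-fold lower number from compound 1 to compound 3 (0.23 log units; within the scatter)). Butylamino has no ring and 1 hydrogen-bond donor, whereas 3-methyl-1H-pyrazol-1-yl has one five-membered aromatic ring and 0 hydrogen-bond donors, so in this pair neither the open chain nor the donor is needed for a number in this range. Nothing available accounts for why these two different groups read alike.

On these data alone, it remains open how a plain pyrazol-1-yl without the methyl, a morpholine or a carboxylic acid would read at this carbon. Compound 2 differs from compound 1 in both the pyrrolidinyl group and the missing chloro group, so the share of either in its higher number cannot be read.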